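The source may report more compounds than this note shows. Statements on the series, on what has been measured and on what is new or still open speak of the compounds shown alone.

Measured in a functional assay on 1321-N1 cells for agonist activity at P2Y purinoceptor 4 (Homo sapiens), read by scintillation counting and inositol phosphate accumulation; a higher number here means that more compound is needed for the effect, a lower number that less compound is needed:
compound 1 `O=C(O)CCCO/N=c1/ccn([C@@H]2O[C@H](COP(=O)(O)OP(=O)(O)OP(=O)(O)O)[C@@H](O)[C@H]2O)c(=O)[nH]1`: 470 nM
compound 2 `O=c1[nH]/c(=N\OCCCCc2ccccc2)ccn1[C@@H]1O[C@H](COP(=O)(O)OP(=O)(O)OP(=O)(O)O)[C@@H](O)[C@H]1O`: 54 nM
compound 3 `O=c1[nH]/c(=N\OCCCc2cccc(F)c2)ccn1[C@@H]1O[C@H](COP(=O)(O)OP(=O)(O)OP(=O)(O)O)[C@@H](O)[C@H]1O`: 100 nM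

Compound 2 gives the lowest of the three numbers in this assay; compound 3 sits closest, a 1.9-fold higher number from compound 2 to compound 3 (0.27 log units; within the scatter), while compound 1 is furthest, an 8.7-fold lower number from compound 1 to compound 2 (0.94 log units; beyond the scatter). Compound 4 `O=c1[nH]/c(=N\OCCCc2cccc([N+](=O)[O-])c2)ccn1[C@@H]1O[C@H](COP(=O)(O)OP(=O)(O)OP(=O)(O)O)[C@@H](O)[C@H]1O` is the next case: 3-nitrophenyl in place of benzyl on a saturated chain carbon, three bonds along the chain from an oxygen. The step that bears on it is the swap of the ring at the same place, a 1.9-fold higher number from compound 2 to compound 3 (0.27 log units; within the scatter), which stayed within the scatter; a 4.7-fold lower number from compound 1 to compound 3 (0.67 log units; beyond the scatter) only confirms that an aryl-ended chain beats the carboxy chain. A ring substituent change in this assay is therefore expected to move the number little, if at all, with a lean toward a slightly higher value: compound 4 is estimated at 100 nM (range 40 nM to 250 nM), a step of a 1.9-fold higher number from compound 2 to compound 4 (0.27 log units; within the scatter) that is expected to stay within the scatter.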

Compound 4, half-maximal effective concentration: 95 nM
The estimate for compound 4 lay 1.1-fold (0.02 log units) above the measured number; low and high end bracket the measured number.
By their numbers in this assay, from the lowest: compounds 2, 4 and 3 (each within the scatter of the next); then compound 1.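

In this assay, nitro in place of fluoro on an aromatic carbon gives no separable difference (a 1.1-fold lower number from compound 3 to compound 4 (0.02 log units; within the scatter)), and 3-nitrophenyl in place of benzyl also stays within the scatter (a 1.8-fold higher number from compound 2 to compound 4 (0.25 log units; within the scatter)), so compounds 2, 3 and 4 cannot be told apart. The gap to the carboxy chain also holds with the nitro-bearing ring (a 4.9-fold lower number from compound 1 to compound 4 (0.69 log units; beyond the scatter)). No measured data are available to explain these steps.

From the compounds shown here alone, whether an amine or a carboxylic acid on the same aromatic carbon would stay within the scatter remains open. So does the effect of a longer chain carrying the 3-nitrophenyl ring.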